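Second chloro on the aryl imine of the pyrazolone series

The source may hold more compounds than are shown below. What is called first, only, known or untested is meant among the compounds shown, and "the series" means these compounds.

Two aryl imines of the shared core have been measured in a functional assay on HCT-116 cells (Homo sapiens) for cytotoxicity, read by MTT assay, with a stated time of 72 h; on this read-out lower numbers stand for stronger inhibition and higher numbers for weaker inhibition. Compound 1 `COc1ccc(/C=N/c2c(C)n(C)n(-c3ccccc3)c2=O)cc1` carries a methoxy group and gives 575000000 nM. Compound 2 `Cc1c(/N=C/c2ccc(Cl)cc2)c(=O)n(-c2ccccc2)n1C` carries a chloro group in its place and gives 589000000 nM. Going by the values given here, the only single-point step recorded, a 1.0-fold higher number from compound 1 to compound 2 (0.01 log units; within the scatter), is within the scatter. Compound 2 therefore holds the higher of the two numbers, but its nearest neighbour is compound 1 at a distance that is within the scatter, so no order between them can be stated.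

Compound 3 `Cc1c(/N=C/c2ccc(Cl)cc2Cl)c(=O)n(-c2ccccc2)n1C` is the next member. Relative to compound 2 the change is chloro in place of hydrogen on an aromatic carbon. Among the compounds with values here, no measured step adds a second chloro to this ring; the single step on record exchanges one substituent for another and is within the scatter, so no information exists on what a further chloro does here. The expected step in this assay is a 1.0-fold lower number from compound 2 to compound 3 (0.01 log units; within the scatter), which is no change beyond the scatter. For compound 3 the estimate in this assay is 580000000 nM, with a range from 150000000 nM to 2300000000 nM.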

Compound 3, half-maximal inhibitory concentration: 269000000 nM
Estimate against measurement, compound 3: 2.2-fold (0.33 log units) above; low and high end bracket the measured number.
By their numbers in this assay, from the lowest: compound 3; then compounds 1 and 2 (each within the scatter of the next).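

In this assay, going by these compounds alone, chloro in place of hydrogen on an aromatic carbon, ortho to a large group and meta to a chloro group, gives a 2.2-fold lower number from compound 2 to compound 3 (0.34 log units; beyond the scatter) and so provides the first step that lies beyond the scatter. The wider exchange of 4-methoxyphenyl for 2,4-dichlorophenyl gives a 2.1-fold lower number from compound 1 to compound 3 (0.33 log units; beyond the scatter) and points the same way, while compound 1 and compound 2 remain within the scatter of each other, so this ring can register a modest shift even though the earlier exchange of one substituent for another showed none. No measurement available here accounts for the step, which remains an observation on these three compounds alone.

The compounds shown leave open whether a methyl group, a fluoro group, an amine or a carboxylic acid on this same aromatic carbon would shift the number in the same direction or by a similar amount. They also leave open whether the step depends on the chloro group already on the ring, or whether the added chloro would give a similar step alongside the methoxy group of compound 1.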